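The source may hold more compounds than are shown below. What is called first, only, known or untested is meant among the compounds shown, and "the series" means these compounds.

Three sugar variants of one core have been run in a functional assay on BXPC-3 cells (Homo sapiens) for cytotoxicity; on this read-out higher numbers stand for weaker inhibition and lower numbers for stronger inhibition. Compound 1 `C[C@@H]1O[C@@H](n2c3ccccc3c3c4c(c5c6ccccc6ccc5c32)C(=O)NC4=O)[C@H](O)[C@H](O)[C@H]1O` gives 7300 nM. Compound 2 `O=C1NC(=O)c2c1c1c3ccccc3ccc1c1c2c2ccccc2n1[C@@H]1O[C@H](CO)[C@@H](O)[C@H](O)[C@H]1O` gives 5400 nM in this assay. Compound 3 `O=C1NC(=O)c2c1c1c3ccccc3ccc1c1c2c2ccccc2n1[C@@H]1O[C@H](CO)[C@@H](O)[C@H]1O` gives 5300 nM in this assay, and its number sits within the scatter of both other compounds, so the three stand together rather than apart. The step of a 1.4-fold lower number from compound 1 to compound 2 (0.13 log units; within the scatter), the step of a 1.4-fold lower number from compound 1 to compound 3 (0.14 log units; within the scatter) and the step of a 1.0-fold lower number from compound 2 to compound 3 (0.01 log units; within the scatter) are all within the scatter: exchanging one sugar group for another on the aromatic nitrogen has not moved the number in any of the three cases.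

Compound 4 `O=C1NC(=O)c2c1c1c3ccccc3ccc1c1c2c2ccccc2n1[C@H]1C[C@H](O)[C@@H](CO)O1` differs from compound 3 by hydrogen in place of hydroxy on a saturated ring carbon. This loss of a single hydroxy from the sugar is a change of the same kind as the three measured ones, each of which stayed within the scatter, so no step beyond the scatter is expected in this assay either. Compound 4 is therefore expected at 5300 nM with a range from 2200 nM to 13000 nM, an expected step of no change at the digits printed from compound 3 to compound 4 (within the scatter).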

Compound 4, half-maximal inhibitory concentration: 7400 nM
For compound 4 the middle estimate is 1.4-fold (0.14 log units) below the measured one, and the stated range covers the measured number.
By their numbers in this assay, from the lowest: compounds 3, 2, 1 and 4 (each within the scatter of the next).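

Hydrogen in place of hydroxy on this saturated ring carbon, next to the ring atom that bears a large group, gives a 1.4-fold higher number from compound 3 to compound 4 (0.14 log units; within the scatter) in this assay, so the number does not depend on this hydroxy in this pair. The 4-hydroxy-5-(hydroxymethyl)oxolan-2-yl group also stays level with both oxane sugars, with a 1.4-fold higher number from compound 2 to compound 4 (0.14 log units; within the scatter) and a 1.0-fold higher number from compound 1 to compound 4 (0.01 log units; within the scatter) on the aromatic nitrogen, and all four compounds now lie within the scatter of one another.

As far as these compounds go, it remains open whether an amine or a carboxylic acid on this ring carbon would move the number. The same holds for a longer chain in place of the hydroxymethyl group, and for any change to the shared core, which is the same in all four compounds. No measurement at hand explains why these sugar changes leave the number in place.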